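The source may report more compounds than this note shows. Statements on the series, on what has been measured and on what is new or still open speak of the compounds shown alone.

Of the compounds shown here, two built on the same core have so far been tested in an assay on cells for inhibition of Amine oxidase [flavin-containing] B (Homo sapiens), read by fluorescence, with stated times of 10 min and 20 min, tested at 25 uM; on this read-out higher numbers stand for more inhibition at the one concentration tested (going by the name of the read-out) and lower numbers for less inhibition. Compound 1 `CC(C)=CCC/C(C)=C/CC/C(C)=C/CC1=C(C)C(=O)C(O)=C(O)C1=O`, carrying the longest chain of the group, gives 93.1% in this assay. Compound 2 `CC(C)=CCC1=C(C)C(=O)C(O)=C(O)C1=O`, with a far shorter chain, gives 38.3% in this assay; that is the lowest of the two numbers, and its gap to compound 1 lies beyond the usual scatter.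

Compound 3 `CC(C)=CCC/C(C)=C/CC1=C(C)C(=O)C(O)=C(O)C1=O` has not yet been measured. It differs from compound 2 by 3-methylbut-2-en-1-yl in place of hydrogen on a saturated chain carbon bound to a double-bonded chain carbon, so its chain is longer than that of compound 2 and shorter than that of compound 1. Because compound 1 with its longer chain reaches 93.1%, a rise beyond the scatter is expected on going to compound 3, roughly a number 31.7 percentage points higher from compound 2 to compound 3 (beyond the scatter). Compound 3 is therefore estimated at 70%, with a likely range from 50% to 90%.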

Compound 3, a percentage reported as inhibition, at one concentration (the size of the read-out at that concentration, not a potency): 92.2%
Beside the measured number, compound 3's estimate is 22.2 percentage points below it; measured number outside the range, above it.
By their numbers in this assay, from the lowest: compound 2; then compounds 3 and 1 (each within the scatter of the next).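

Placing 3-methylbut-2-en-1-yl on a saturated chain carbon bound to a double-bonded chain carbon gives a number 53.9 percentage points higher from compound 2 to compound 3 (beyond the scatter) in this assay, so this single addition covers almost all of the gap between the short and the long chain. The same exchange made on the longer chain gives a number 0.9 percentage points lower from compound 1 to compound 3 (within the scatter), so at this position the group matters greatly on the short chain, while no difference can be read on the longer one. No measurement at hand explains this contrast.

As far as these compounds go, whether a longer chain, a fully saturated chain or a chain ending in a carboxylic acid would keep this level of inhibition remains open. From the compounds shown here alone, with only a single concentration tested, it also remains open whether compound 1 and compound 3 would separate at lower concentrations.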